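Aryl substituent series on the shared core: ester step

The compounds below may be only part of what the source reports. "The series", "measured", "known", "first", "only" and "open" are said of these compounds alone.

Measured compounds:
compound 1 `CCCc1ccc(/C=C2\CCCN=C2c2cccnc2)cc1`, 890 nM
compound 2 `CC(=O)c1ccc(/C=C2\CCCN=C2c2cccnc2)cc1`, 4490 nM
compound 3 `COc1ccc(/C=C2\CCCN=C2c2cccnc2)cc1`, 490 nM

In an assay on membranes from brain for displacement of a labelled ligand from Neuronal acetylcholine receptor; alpha4/beta2 (Rattus norvegicus), with a stated time of 3 h (on this read-out higher numbers stand for weaker inhibition and lower numbers for stronger inhibition), compound 3 holds the lowest of the three numbers; compound 1 lies within the scatter of it, compound 2 beyond it. Compound 4 `CC(C)(C)C(=O)Oc1ccc(/C=C2\CCCN=C2c2cccnc2)cc1` differs from compound 3 by (tert-butyl)carbonyl in place of methyl on an oxygen on an aromatic ring. Among the measured compounds shown here, the steps that bear on this are the two that add or remove a carbonyl on the aromatic substituent: a 5.0-fold higher number from compound 1 to compound 2 (0.70 log units; beyond the scatter) and a 9.2-fold lower number from compound 2 to compound 3 (0.96 log units; beyond the scatter). Compound 4 keeps the oxygen on the aromatic ring of compound 3 but gains a carbonyl, so a modest rise in the number is expected, a 3.1-fold higher number from compound 3 to compound 4 (0.49 log units; beyond the scatter), smaller than the acetyl steps. Compound 4 is estimated at 1500 nM, with a range from 500 nM to 5000 nM.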

Compound 4, inhibition constant: 830 nM
The estimate for compound 4 lay 1.8-fold (0.26 log units) above the measured number; the range from low to high includes it.
By their numbers in this assay, from the lowest: compounds 3, 4 and 1 (each within the scatter of the next); then compound 2.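

In this assay, the methoxy group can give way to ((tert-butyl)carbonyl)oxy with no change beyond the scatter (a 1.7-fold higher number from compound 3 to compound 4 (0.23 log units; within the scatter)), and the ester also stays within the scatter of the propyl compound (a 1.1-fold lower number from compound 1 to compound 4 (0.03 log units; within the scatter)). A carbonyl in this substituent therefore does not by itself raise the number, as the ester and acetyl compounds, which both carry one, stand well apart (a 5.4-fold lower number from compound 2 to compound 4 (0.73 log units; beyond the scatter)). Nothing measured here accounts for that gap.

Open, going by these compounds, is whether a carboxylic acid, an amine or a longer chain at this aromatic carbon would stay with compound 1, compound 3 and compound 4 or move towards compound 2.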